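This account rests on a few compounds, and the source may have more. Where it says the series, first, only, none or still open, it means among the compounds named here.

Of the compounds shown here, two have been measured so far. Compound 1 `CN1CCC(n2nc(C#Cc3cccc(C(=O)Nc4cccc(C(F)(F)F)c4)c3)c3c(N)ncnc32)CC1` and compound 2 `Cc1ccc(NC(=O)c2cnc(C(C)(C)C)s2)cc1C#Cc1nn(C[C@@H](C)CO)c2ncnc(N)c12` share the same core and differ in the group attached to the amide carbonyl and in the substituent on the core. In an ADME assay on HepG2 cells (Homo sapiens) for antiproliferative activity, read by MTT assay, with a stated time of 72 h (on this read-out higher numbers stand for weaker inhibition and lower numbers for stronger inhibition), compound 1 gives > 10000 nM, which is a limit of the assay and not a number. In this assay compound 2 gives > 10000 nM, likewise a limit and not a number. Both readings sit at the limit of > 10000 nM in this assay, at which 2 of the 2 values shown sit, so the data place compound 2 nowhere in particular: they only show that neither compound reached a measurable value.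

Compound 3 `Cc1ccc(NC(=O)c2ccc(Cl)c(C(F)(F)F)c2)cc1C#Cc1nn(C[C@@H](C)CO)c2ncnc(N)c12` is the next to be tested. It differs from compound 2 in one place: 4-chloro-3-(trifluoromethyl)phenyl in place of 2-(tert-butyl)-1,3-thiazol-5-yl on a carbonyl carbon. Among the measured compounds shown here, no step between two measured compounds exists to indicate what such a change does, and with both readings resting at the limit of > 10000 nM in this assay, at which 2 of the 2 values shown sit, there is no anchor for direction. The step of a number no higher from compound 2 to compound 3 (the limit leaves the size open) is expected to stay within the usual scatter, with a further limit reading as the most likely outcome. For compound 3 the estimate in this assay is 10000 nM, within a range from 3000 nM to 30000 nM.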

Compound 3, half-maximal inhibitory concentration: > 10000 nM
Compound 3 gave a limit, no number (the forecaster's own chance of this, stated with the estimate: 65%); the middle value lies on the limit itself.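

Swapping 2-(tert-butyl)-1,3-thiazol-5-yl for 4-chloro-3-(trifluoromethyl)phenyl from compound 2 to compound 3 gives no readable step in this assay, because both readings are limits and not numbers: the limit of > 10000 nM in this assay, at which 3 of the 3 values shown sit.

The compounds shown leave open how these two groups truly compare and which changes to the shared core would give a measurable value.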